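A few compounds are considered here, and "the series" means these few. Any claim that something is new, unique, unknown or untested is made for them only; others in the source may bear on it.

Measured so far in an ADME assay on microsomes from liver (Homo sapiens) for metabolic stability, read by LC-MS, using NADPH; on this read-out higher numbers stand for a longer-lived compound and lower numbers for a shorter-lived compound:
- compound 1 `CCC(C)(C)C(=O)N(O)Cc1cc(F)cc(F)c1F`: 1.11 h
- compound 2 `CCC(C)(C)C(=O)N(O)Cc1ccc(F)c(F)c1F`: 0.882 h
- compound 3 `CCC(C)(C)C(=O)N(O)Cc1ccc(F)cc1F`: 3.3 h

Compound 3 stands highest of the three, and its gaps to compound 1 and compound 2 both lie beyond the scatter. Compound 4 `CCC(C)(C)C(=O)N(O)Cc1ccc(F)cc1` follows from compound 3 by one change, hydrogen in place of fluoro on an aromatic carbon, ortho to a large group and meta to a fluoro group.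

Going by the values given here, one measured step bears on this, a 3.7-fold higher number from compound 2 to compound 3 (0.57 log units; beyond the scatter). It is the same exchange, made at a different ring carbon, and it is modest in size. With a single precedent from another place on the ring, its direction is carried over only weakly, so a small rise that stays within the scatter is expected in this assay.

The expected step is a 1.2-fold higher number from compound 3 to compound 4 (0.06 log units; within the scatter). For compound 4 the estimated half-life is 3.8 h, with an expected range of 1.8 h to 8 h.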

Compound 4, half-life: 2.97 h
Compound 4: the middle estimate sits 1.3-fold (0.11 log units) above what was measured, and the stated range covers the measured number.
By their numbers in this assay, from the lowest: compounds 2 and 1 (each within the scatter of the next); then compounds 4 and 3 (each within the scatter of the next).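

In this assay, hydrogen in place of fluoro on an aromatic carbon, ortho to a large group and meta to a fluoro group, gives a 1.1-fold lower number from compound 3 to compound 4 (0.05 log units; within the scatter). The same exchange at another ring carbon gave a 3.7-fold higher number from compound 2 to compound 3 (0.57 log units; beyond the scatter), so across these two pairs the size of the step depends on the ring carbon, and at this position the fluoro group can go without a change beyond the scatter. Nothing shown accounts for the difference between the two ring carbons.

Still open, going by these compounds, is how a methoxy group, a chloro group or a nitrile at this position would compare with hydrogen and fluoro. Also open, on these data alone, is whether the same flat step would hold with an amine or a longer chain elsewhere on the shared core.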